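This account rests on a few compounds, and the source may have more. Where it says the series, first, only, none or still open, it means among the compounds named here.

For the measured compounds named here, in an assay on HEK293 cells for displacement of a labelled ligand from growth hormone secretagogue receptor type 1 (Homo sapiens), with a stated time of 60 min (a lower number here means a stronger inhibitor, a higher number a weaker inhibitor), compound 3 `CCN(CC)CCCS(=O)(=O)c1ccc2nc(NC(=O)NC(=O)c3ccccc3Cl)sc2c1` gives 13 nM, the lowest of the three numbers measured so far. Compound 1 `CC(C)NCCS(=O)(=O)c1ccc2nc(NC(=O)NC(=O)c3ccccc3Cl)sc2c1` gives 27 nM, and compound 2 `CS(=O)(=O)c1ccc2nc(NC(=O)NC(=O)c3ccccc3Cl)sc2c1` gives 120 nM. The measured steps all concern the chain on the sulfonyl sulfur: a 4.4-fold higher number from compound 1 to compound 2 (0.65 log units; beyond the scatter), a 9.2-fold lower number from compound 2 to compound 3 (0.97 log units; beyond the scatter), and a 2.1-fold lower number from compound 1 to compound 3 (0.32 log units; beyond the scatter). Each of these is modest, and the two that add or rework the amine-bearing chain both lower the number.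

Compound 4 `CN1CCCN(CCCS(=O)(=O)c2ccc3nc(NC(=O)NC(=O)c4ccccc4Cl)sc3c2)CC1` differs from compound 3 in one place: 4-methyl-1,4-diazepan-1-yl in place of diethylamino on a saturated chain carbon, three bonds along the chain from a sulfonyl sulfur. The measured steps bear on this change only indirectly, since none of them exchanges one tertiary amine for another while keeping the chain the same. What they do show is that the amine-bearing chain as a whole matters for this assay, with compound 2, which lacks it, giving the highest number, and that exchanging isopropylamino for diethylamino with a longer chain moved the number only modestly. A cyclic amine in place of diethylamino is therefore expected to give at most a modest step, and most likely one that stays within the scatter. Compound 4 is estimated at 11 nM, with a range from 4 nM to 30 nM, which means an expected step of a 1.2-fold lower number from compound 3 to compound 4 (0.07 log units; within the scatter).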

Compound 4, half-maximal inhibitory concentration: 4.2 nM
For compound 4 the middle estimate is 2.6-fold (0.42 log units) above the measured one; the range from low to high includes it.
By their numbers in this assay, from the lowest: compound 4; then compound 3; then compound 1; then compound 2.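

In this assay, the place on a saturated chain carbon, three bonds along the chain from a sulfonyl sulfur, responds to the identity of the amine and not only to the presence of an amine-bearing chain: 4-methyl-1,4-diazepan-1-yl in place of diethylamino gives a 3.1-fold lower number from compound 3 to compound 4 (0.49 log units; beyond the scatter) and is beyond the scatter. Measured against the hydrogen-ended chain, the same group gives a 29-fold lower number from compound 2 to compound 4 (1.46 log units; beyond the scatter) as the only large step in the series, and measured against the isopropylamino chain it gives a 6.4-fold lower number from compound 1 to compound 4 (0.81 log units; beyond the scatter) so that the seven-membered ring sits at the low end of all the numbers shown. No evidence is available that bears on what lies behind this result.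

The compounds shown leave open whether the lower number goes with the seven-membered ring or with the second ring nitrogen, a question that 4-methylpiperazin-1-yl, piperidin-1-yl or morpholin-4-yl at this place would bear on. They also leave open how 4-methyl-1,4-diazepan-1-yl behaves on a shorter chain such as that of compound 1, as it appears here only on the 3-(4-methyl-1,4-diazepan-1-yl)propyl chain.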